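The source may hold more compounds than are shown below. What is called first, only, known or untested is meant among the compounds shown, and "the series" means these compounds.

Measured so far:
Compound 1 `COc1cc(-c2nn(-c3cccc(NC(=O)c4ccc(Cl)c(C(F)(F)F)c4)c3)cc2-c2ccncc2)ccc1Cl` — > 32500 nM, a limit of the assay.
Compound 2 `O=C(Nc1cccc(-n2cc(-c3ccncc3)c(-c3ccc(Cl)c(O)c3)n2)c1)Nc1cc(C(F)(F)F)cc(C(F)(F)F)c1` — 2920 nM.

In a functional assay on COLO 205 cells (Homo sapiens) for inhibition, read by sulforhodamine B assay, with a stated time of 48 h (a lower number here means that less compound is tolerated, a higher number that more compound is tolerated), compound 2 gives 2920 nM, the only number shown. For compound 1 the result is > 32500 nM, a limit rather than a number, so compound 2 stands alone as the single measured figure, with the limit of > 32500 nM in this assay, at which 1 of the 2 values shown sits, beside it. Compound 3 `O=C(Nc1cccc(-n2cc(-c3ccncc3)c(-c3ccc(Cl)c(O)c3)n2)c1)Nc1cccc(C(F)(F)F)c1` is still to be measured. It differs from compound 2 by hydrogen in place of trifluoromethyl on an aromatic carbon. Going by the values given here, no measured step of this kind is available, so the size of the effect is open; a modest loss, near the edge of the scatter, is expected. Compound 3 is estimated at 4500 nM, in the range 1500 nM to 15000 nM, which means an expected step of a 1.5-fold higher number from compound 2 to compound 3 (0.19 log units; within the scatter).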

Compound 3, concentration lethal to 50% of the cells: > 32500 nM
Compound 3 ended at the assay's limit; the forecaster's own chance of this, stated with the estimate: 10%; middle value at least 7.2-fold (0.85 log units) away from the limit.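

In this assay, this position on the six-membered aromatic ring of carbon only matters: with hydrogen in place of trifluoromethyl there is an at least 11-fold higher number from compound 2 to compound 3 (1.04 log units; beyond the scatter). Going by these compounds alone, this is the first measured step here, and it shows that the number of compound 2 depends on this group. The true size of the step stays unknown, as the reading for compound 3 is a limit of the assay, one shared across the set: the limit of > 32500 nM in this assay, at which 2 of the 3 values shown sit.

Going by these compounds, whether a chlorine or a methyl at this position would hold the number of compound 2 stays open. So does whether the same change acts alike on the core of compound 1.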